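The source may report more compounds than this note shows. Statements on the series, on what has been measured and on what is new or still open speak of the compounds shown alone.

Measured so far:
- compound 2, `O=C(NCc1cn(Cc2ccc3oc(-c4ccccc4)cc(=O)c3c2)nn1)c1ccccc1`: 15600 nM
- compound 1, `Cc1ccc(NC(=O)CCCCc2cn(Cc3ccc4oc(-c5ccc(Cl)cc5)cc(=O)c4c3)nn2)cc1`: 32900 nM
- compound 3, `Cc1ccc(C(=O)NCc2cn(Cc3ccc4oc(-c5ccc(Cl)cc5)cc(=O)c4c3)nn2)cc1`: 32900 nM

All three compounds share the same core and were tested in an assay on isolated protein for inhibition of Amine oxidase [flavin-containing] B (Homo sapiens), read by fluorescence and spectrophotometry; on this read-out lower numbers stand for stronger inhibition and higher numbers for weaker inhibition. Compound 2 stands lowest of the three numbers; in this assay compound 2 gives 15600 nM, and both compound 1 and compound 3 sit above it by a margin that the assay's usual scatter does not account for, so compound 2 shows the strongest inhibition among them. Compound 1 gives 32900 nM and compound 3 gives 32900 nM.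

Compound 4, `O=C(CCc1cn(Cc2ccc3oc(-c4ccccc4)cc(=O)c3c2)nn1)Nc1ccc(Cl)cc1`, has not yet been measured. Compared with compound 2, the change is ((4-chlorophenyl)carbamoyl)methyl in place of benzamido on a saturated chain carbon bound to an aromatic carbon. Among the compounds with values here, no measured pair in this set isolates such a change, so the expectation rests on the spread of the three numbers above. Because compound 3 gives 32900 nM and compound 1 gives 32900 nM, a modest step toward a higher number from compound 2 to compound 4 is expected, probably not far beyond the scatter: a 1.6-fold higher number from compound 2 to compound 4 (0.20 log units; within the scatter). Compound 4 is therefore estimated at 25000 nM, within a range from 10000 nM to 60000 nM.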

Compound 4, half-maximal inhibitory concentration: 15600 nM
Beside the measured number, compound 4's estimate is 1.6-fold (0.20 log units) above it; the range from low to high includes it.
By their numbers in this assay, from the lowest: compounds 2 and 4 (each within the scatter of the next); then compounds 1 and 3 (each within the scatter of the next).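

In this assay, placing ((4-chlorophenyl)carbamoyl)methyl in place of benzamido, on a saturated chain carbon bound to an aromatic carbon, gives no change at the digits printed from compound 2 to compound 4 (within the scatter). Within the data shown here, this is the first comparison here of compounds that differ in only one place, and it shows that this position can take a larger group carrying a chlorine with no measurable shift in the reading, while each group keeps one six-membered aromatic ring, one hydrogen-bond donor and one hydrogen-bond acceptor. Nothing available explains why the reading holds steady.

From the compounds shown here alone, the chlorine and the rearranged chain changed together, so their separate contributions remain unknown, and they may or may not offset each other. The compounds shown also leave open how this position responds to a group without an aromatic ring, such as a carboxylic acid or an amine.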